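This account rests on a few compounds, and the source may have more. Where it says the series, first, only, none or still open, it means among the compounds named here.

Measured compounds:
compound 1 `Cc1noc(C)c1-c1cnc(N)c(Oc2ccc(C(=O)Nc3cc(Cl)ccn3)cc2)n1` gives 37900 nM in a functional assay on HeLa cells (Homo sapiens) for inhibition, read by MTT assay, with a stated time of 72 h; a lower number here means a stronger inhibitor, a higher number a weaker inhibitor;
compound 2 `Cn1cc(-c2cnc(N)c(Oc3ccc(C(=O)Nc4ccccc4)cc3)n2)cn1` gives 12300 nM in this assay;
compound 3 `Cn1cc(-c2cnc(N)c(Oc3ccc(C(=O)Nc4cccc(Cl)c4)cc3)n2)cn1` gives 4460 nM in this assay.

Compound 3 gives the lowest number of the three. Among the compounds with values here, the only step among the measured compounds is a 2.8-fold lower number from compound 2 to compound 3 (0.44 log units; beyond the scatter); it concerns a chloro substituent, not the change now in question. Compound 4 `Cn1cc(-c2cnc(N)c(Oc3ccc(C(=O)Nc4cc(Cl)ccn4)cc3)n2)cn1` carries 4-chloropyridin-2-yl in place of 3-chlorophenyl on an amide-type nitrogen. Within the data shown here, no measured pair shows this exchange directly. Compound 1 carries the same 4-chloropyridin-2-yl amide on a different core and gives a high number, while compound 3 gives a markedly lower one; the two cores differ, so the comparison is loose. A weaker result is therefore expected for compound 4, a 2.7-fold higher number from compound 3 to compound 4 (0.43 log units; beyond the scatter), with the estimate 12000 nM and range 3000 nM to 45000 nM.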

Compound 4, half-maximal inhibitory concentration: 40800 nM
Compound 4: middle estimate off by 3.4-fold (0.53 log units), on the low side; the range from low to high includes it.
By their numbers in this assay, from the lowest: compound 3; then compound 2; then compounds 1 and 4 (each within the scatter of the next).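

In this assay placing 4-chloropyridin-2-yl on the amide-type nitrogen gives a 9.1-fold higher number from compound 3 to compound 4 (0.96 log units; beyond the scatter) and a 3.3-fold higher number from compound 2 to compound 4 (0.52 log units; beyond the scatter) on the shared core, so this group falls behind both the 3-chlorophenyl and the phenyl amide. With this amide held constant, the 1-methyl-1H-pyrazol-4-yl exchange gives a 1.1-fold higher number from compound 1 to compound 4 (0.03 log units; within the scatter) and separates neither compound from the other. Nothing measured here explains the loss.

Since the ring nitrogen and the chloro position both differ from compound 3, the compounds shown cannot say which matters. Also open, on these data alone, is whether pyridin-2-yl without chloro, or a methoxy or nitrile in place of that chloro, would recover the lower numbers.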